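Shortening the Chain on the Ring Nitrogen

The source may hold more compounds than are shown below. What is called first, only, known or untested is meant among the compounds shown, and "the series" means these compounds.

Measured compounds:
compound 1 `COc1cc(Cc2nc3c(N)ncnc3n2CC(C)C)cc(OC)c1OC`: 97700 nM
compound 2 `C#CCCCn1c(Cc2cc(OC)c(OC)c(OC)c2)nc2c(N)ncnc21`: 24000 nM
compound 3 `CC/C=C\Cn1c(Cc2cc(OC)c(OC)c(OC)c2)nc2c(N)ncnc21`: 64600 nM

All three compounds share one core and differ only in the chain on a saturated chain carbon bound to an aromatic nitrogen. In a functional assay on MCF7 cells (Homo sapiens) for antiproliferative activity (a higher number here means a weaker inhibitor, a lower number a stronger inhibitor), compound 3 holds the second highest number of the three. Its nearest neighbour is compound 1, with a 1.5-fold lower number from compound 1 to compound 3 (0.18 log units; within the scatter), a gap that is within the scatter; its furthest is compound 2, with a 2.7-fold higher number from compound 2 to compound 3 (0.43 log units; beyond the scatter), a gap beyond the scatter.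

Compound 4 `CCCn1c(Cc2cc(OC)c(OC)c(OC)c2)nc2c(N)ncnc21` is the next step: ethyl in place of but-1-en-1-yl on a saturated chain carbon bound to an aromatic nitrogen. Among the compounds with values here, no measured step removes carbons from this chain, so none bears on it directly. What the measured steps do show is that exchanging isopropyl for but-1-en-1-yl, a 1.5-fold lower number from compound 1 to compound 3 (0.18 log units; within the scatter), stayed within the scatter, whereas the chain with a triple bond stood apart, a 4.1-fold lower number from compound 1 to compound 2 (0.61 log units; beyond the scatter). Compound 1, like compound 4, carries a saturated chain, and it sits close to compound 3. Compound 4 is therefore expected to land near compounds 1 and 3, with a 1.2-fold higher number from compound 3 to compound 4 (0.09 log units; within the scatter) and an estimated value of 80000 nM, ranging from 25000 nM to 250000 nM.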

Compound 4, half-maximal inhibitory concentration: 46800 nM
Beside the measured number, compound 4's estimate is 1.7-fold (0.23 log units) above it; low and high end bracket the measured number.
By their numbers in this assay, from the lowest: compounds 2, 4, 3 and 1 (each within the scatter of the next, the first and the last beyond it).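

In this assay, the propyl chain of compound 4 shows that this position tolerates ethyl in place of but-1-en-1-yl, with a 1.4-fold lower number from compound 3 to compound 4 (0.14 log units; within the scatter) staying within the scatter, and that the ethynyl end can also give way to hydrogen, with a 2.0-fold higher number from compound 2 to compound 4 (0.29 log units; within the scatter) likewise within the scatter. Compound 4 therefore lies within the scatter of two compounds that remain apart from each other, a 2.7-fold higher number from compound 2 to compound 3 (0.43 log units; beyond the scatter), so the triple bond no longer marks out a clearly separate result. Within the data shown here, the only new step beyond the scatter is hydrogen in place of methyl on a saturated chain carbon bound to two saturated chain carbons, a modest change with a 2.1-fold lower number from compound 1 to compound 4 (0.32 log units; beyond the scatter), which suggests that removing this branch may matter more here than the other new changes, though the step is small.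

Nothing available explains why these chains give these numbers. The compounds shown leave open whether a much shorter chain such as methyl, a longer chain, or a chain ending in an amine or a carboxylic acid would shift the number further in this assay.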